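Replacing a methoxyphenyl with a fluorophenyl on the enone chain

This account rests on a few compounds, and the source may have more. Where it says the series, first, only, none or still open, it means among the compounds named here.

Of the compounds shown here, three sharing one core have been tested in an ADME assay on the whole organism for cytotoxicity, with Artemia salina as the target, with a stated time of 24 h; on this read-out higher numbers stand for an effect only at larger amounts of compound and lower numbers for an effect already at smaller amounts. Compound 1 `Cc1ccc(/C=C/C(=O)c2ccccc2NC(=O)NS(=O)(=O)c2ccc(C)cc2)cc1` gives 15.3 ug/mL. Compound 2 `COc1cccc(/C=C/C(=O)c2ccccc2NC(=O)NS(=O)(=O)c2ccc(C)cc2)c1` gives 23.2 ug/mL, and compound 3 `COc1ccc(/C=C/C(=O)c2ccccc2NC(=O)NS(=O)(=O)c2ccc(C)cc2)cc1OC` gives 12.9 ug/mL. Compound 2 sits at the upper end of the three numbers, yet its steps to both others stay within the scatter: a 1.5-fold higher number from compound 1 to compound 2 (0.18 log units; within the scatter) and a 1.8-fold lower number from compound 2 to compound 3 (0.25 log units; within the scatter), while a 1.2-fold lower number from compound 1 to compound 3 (0.07 log units; within the scatter) is likewise small.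

Compound 4 `Cc1ccc(S(=O)(=O)NC(=O)Nc2ccccc2C(=O)/C=C/c2ccc(F)cc2)cc1` is not yet measured. It differs from compound 2 in one place: 4-fluorophenyl in place of 3-methoxyphenyl on a double-bonded chain carbon bound to a double-bonded chain carbon. All three measured steps touch the same ring on the double-bonded chain carbon, and none of them moves the number beyond the scatter, so exchanges at this position have so far left this assay essentially unchanged.

On that basis compound 4 is expected to give about 16 ug/mL, with a range from 8 ug/mL to 32 ug/mL. The step of a 1.5-fold lower number from compound 2 to compound 4 (0.16 log units; within the scatter) is expected to fall within the scatter, in no clear direction.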

Compound 4, concentration for half-maximal effect: 3.96 ug/mL
Compound 4: middle estimate off by 4.0-fold (0.61 log units), on the high side; measured number below the stated range.
By their numbers in this assay, from the lowest: compound 4; then compounds 3, 1 and 2 (each within the scatter of the next).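

Exchanges on this ring had so far left the number within the scatter, but 4-fluorophenyl on the double-bonded chain carbon moves it beyond the scatter in this assay against all three earlier compounds, with a 5.9-fold lower number from compound 2 to compound 4 (0.77 log units; beyond the scatter) and a 3.3-fold lower number from compound 3 to compound 4 (0.51 log units; beyond the scatter) and also a 3.9-fold lower number from compound 1 to compound 4 (0.59 log units; beyond the scatter) in the same direction. The position is therefore not indifferent to what it carries. The clearest single comparison is fluoro in place of methyl, since those two compounds differ by that one group on the aromatic carbon.

Nothing given here explains the shift. Among the compounds shown here, compound 4 is the only fluorinated example, so whether chloro, bromo or an amine in the place of that fluoro would give a similar number remains open.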